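From 4-Cyanobenzyl to Ethyl: Expecting Compound 4

The source may report more compounds than this note shows. Statements on the series, on what has been measured and on what is new or still open speak of the compounds shown alone.

Compound 1 `N#Cc1ccc(Cn2c(/C=C3\SC(=S)N(CC(=O)O)C3=O)nc3ccccc32)cc1` gives 11200 nM in a functional assay on MDA-MB-231 cells (Homo sapiens) for cytotoxicity, read by MTT assay, with a stated time of 48 h; a lower number here means a stronger inhibitor, a higher number a weaker inhibitor.
Compound 2 `O=C(O)CN1C(=O)/C(=C/c2nc3ccccc3n2Cc2ccc([N+](=O)[O-])cc2)SC1=S` gives 7760 nM in this assay.
Compound 3 `O=C(O)CN1C(=O)/C(=C/c2nc3ccccc3n2Cc2ccc(F)cc2F)SC1=S` gives 11500 nM in this assay.

Compound 1 has the second highest of the three numbers; its gap to compound 3 is a 1.0-fold higher number from compound 1 to compound 3 (0.01 log units; within the scatter) and to compound 2 is a 1.4-fold lower number from compound 1 to compound 2 (0.16 log units; within the scatter), both within the scatter. Compound 4 `CCn1c(/C=C2\SC(=S)N(CC(=O)O)C2=O)nc2ccccc21` differs from compound 1 as follows: methyl in place of 4-cyanophenyl on a saturated chain carbon bound to an aromatic nitrogen. Within the data shown here, the measured steps, including a 1.5-fold higher number from compound 2 to compound 3 (0.17 log units; within the scatter), all swap one aryl group for another and stay within the scatter, so no measured step bears directly on replacing the aryl group with methyl. The expectation for compound 4 in this assay is therefore 16000 nM, with a wide range from 5000 nM to 50000 nM, corresponding to an expected step of a 1.4-fold higher number from compound 1 to compound 4 (0.15 log units; within the scatter).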

Compound 4, half-maximal inhibitory concentration: 1880 nM
Compound 4: the middle estimate sits 8.5-fold (0.93 log units) above what was measured; measured number outside the range, below it.
By their numbers in this assay, from the lowest: compound 4; then compounds 2, 1 and 3 (each within the scatter of the next).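

In this assay, swapping one aryl group for another at this position left the numbers within the scatter, but replacing the aryl group with methyl moves them beyond it (a 6.0-fold lower number from compound 1 to compound 4 (0.78 log units; beyond the scatter)), (a 6.1-fold lower number from compound 3 to compound 4 (0.79 log units; beyond the scatter)) and (a 4.1-fold lower number from compound 2 to compound 4 (0.62 log units; beyond the scatter)). Among these four compounds, the change from a substituted benzyl to ethyl therefore matters more than which aryl substituents are present. No evidence here explains this difference. Still open, on these data alone, is whether the lower number belongs to ethyl alone. A propyl or butyl chain, an unsubstituted benzyl or a chain ending in an amine could show how far it extends.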